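The source may hold more compounds than are shown below. What is called first, only, known or untested is meant among the compounds shown, and "the series" means these compounds.

For the measured compounds named here, compound 1 `CN1CCN(c2nc(NCc3ccc(NC(=O)c4ccc(F)cc4)cc3)c3ccccc3n2)CC1` gives 1800 nM in a functional assay on HCT-116 cells (Homo sapiens) for inhibition, read by luminescence and resazurin assay, with a stated time of 3 days (on this read-out higher numbers stand for weaker inhibition and lower numbers for stronger inhibition), the only plain number recorded among the three measured compounds. Compound 2 `CN1CCN(c2nc(NCc3ccc(NC(=O)c4ccncc4)cc3)c3ccccc3n2)CC1` reaches only the limit > 20000 nM in this assay. Compound 3 `Cc1ccc(S(=O)(=O)Nc2ccc(CNc3nc(N4CCN(C)CC4)nc4ccccc34)cc2)cc1` likewise stops at the limit > 20000 nM. The two steps, an at least 11-fold higher number from compound 1 to compound 2 (1.04 log units; beyond the scatter) and an at least 11-fold higher number from compound 1 to compound 3 (1.04 log units; beyond the scatter), both alter the amide portion, and the limit of > 20000 nM in this assay, at which 2 of the 3 values shown sit, leaves their full size open. Compound 4 `CCNc1nc(NCc2ccc(NC(=O)c3ccc(F)cc3)cc2)c2ccccc2n1` differs from compound 1 elsewhere, at the core: ethylamino in place of 4-methylpiperazin-1-yl on an aromatic carbon. Going by the values given here, no measured step touches that position, so the recorded steps give no direct guide. A moderate weakening is expected, a 2.2-fold higher number from compound 1 to compound 4 (0.35 log units; beyond the scatter), so compound 4 is estimated at 4000 nM, within 1200 nM to 15000 nM.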

Compound 4, half-maximal inhibitory concentration: 1400 nM
For compound 4 the middle estimate is 2.9-fold (0.46 log units) above the measured one; low and high end bracket the measured number.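

In this assay, ethylamino in place of 4-methylpiperazin-1-yl gives a 1.3-fold lower number from compound 1 to compound 4 (0.11 log units; within the scatter). At this aromatic carbon between two ring nitrogen atoms, then, the ring of compound 1 can give way to an open chain with no readable change, whereas the earlier readable steps, both at the amide portion, were large. Nothing recorded here explains this result. The compounds shown leave open whether a morpholine ring, a free amine or a longer alkylamino chain at this position would also leave the value unchanged.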